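The compounds below may be only part of what the source reports. "The series", "measured", "known", "first", "only" and "open" are said of these compounds alone.

Values so far in a functional assay on K562 cells (Homo sapiens) for cytotoxicity, read by trypan blue exclusion, with a stated time of 96 h; a higher number here means a weaker inhibitor, a lower number a stronger inhibitor:
compound 1 `COc1cc(OC)c(/C=C/S(=O)(=O)Cc2ccc(OC)c([N+](=O)[O-])c2)c(OC)c1` gives 2500 nM
compound 2 `COC(=O)CNc1cc(CS(=O)(=O)/C=C/c2c(OC)cc(OC)cc2OC)ccc1OC` gives 100 nM
compound 3 `COC(=O)[C@H](C)Nc1cc(CS(=O)(=O)/C=C/c2c(OC)cc(OC)cc2OC)ccc1OC` gives 200 nM

Compound 3 at 200 nM cannot be told apart from compound 2 (100 nM), and both lie far below compound 1 (2500 nM) in this read-out.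

Compound 4 `COC(=O)C(C)(C)Nc1cc(CS(=O)(=O)/C=C/c2c(OC)cc(OC)cc2OC)ccc1OC` has not yet been measured. Its structure differs from that of compound 3 in one group: 1-(methoxycarbonyl)-1-methylethyl in place of 1-(methoxycarbonyl)ethyl on a nitrogen on an aromatic ring so that 1-(methoxycarbonyl)-1-methylethyl replaces 1-(methoxycarbonyl)ethyl on a nitrogen on an aromatic ring.

The closest measured precedent is the addition of a methyl in place of hydrogen on the same chain carbon, which gave a 2.0-fold higher number from compound 2 to compound 3 (0.30 log units; within the scatter) and so stayed within the scatter. The two large steps, a 25-fold lower number from compound 1 to compound 2 (1.40 log units; beyond the scatter) and a 13-fold lower number from compound 1 to compound 3 (1.10 log units; beyond the scatter) both replace nitro, which is a different kind of change and says little here. With one small precedent to go on, a large step in this assay is not expected, and any shift would more likely be toward a slightly higher number. The expected step is a 1.5-fold higher number from compound 3 to compound 4 (0.18 log units; within the scatter) and this remains only an estimate. For compound 4 the estimated value is 300 nM with an expected range from 100 nM to 900 nM in this measurement.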

Compound 4, half-maximal inhibitory concentration: 800 nM
Compound 4: the middle estimate sits 2.7-fold (0.43 log units) below what was measured; the range from low to high includes it.
By their numbers in this assay, from the lowest: compounds 2 and 3 (each within the scatter of the next); then compound 4; then compound 1.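

In this assay, a second methyl on the same chain carbon, turning 1-(methoxycarbonyl)ethyl into 1-(methoxycarbonyl)-1-methylethyl on the nitrogen, gives a 4.0-fold higher number from compound 3 to compound 4 (0.60 log units; beyond the scatter) and lies beyond the scatter, whereas the first methyl gave a 2.0-fold higher number from compound 2 to compound 3 (0.30 log units; within the scatter) and stayed within it. This position therefore accepts one methyl without a readable change but not two, and the full change from the unbranched (methoxycarbonyl)methyl group amounts to an 8.0-fold higher number from compound 2 to compound 4 (0.90 log units; beyond the scatter). Even so, the most branched amino ester keeps a readable edge over the nitro group, with a 3.1-fold lower number from compound 1 to compound 4 (0.49 log units; beyond the scatter), although much of the gain seen with the unbranched group is lost; nothing shown here explains this loss.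

The compounds shown leave open whether an ethyl or a longer chain on the same carbon would raise the number further, and whether a ring built on that carbon would behave like two separate methyl groups. They also leave open whether a carboxylic acid in place of the methyl ester would follow the same order, and how the mirror-image form of compound 3, with its one defined stereocentre reversed, would compare.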